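The source may hold more compounds than are shown below. What is called first, only, known or untested is meant among the compounds shown, and "the series" means these compounds.

Measured so far:
compound 1 `COc1ccc(C2=NN(C3=NC(=O)/C(=C4\C(=O)Nc5ccc(Br)cc54)S3)C(c3ccc(OC)cc3)C2)cc1`: 200 nM
compound 2 `COc1ccc(C2=NN(C3=NC(=O)/C(=C4\C(=O)Nc5ccccc54)S3)C(c3ccc(Cl)cc3)C2)cc1`: 92400 nM

In a functional assay on cells (Cancer cell lines, Homo sapiens) for cytotoxicity, read by sulforhodamine B assay, with a stated time of 48 h (a lower number here means a stronger inhibitor of growth, a higher number a weaker inhibitor of growth), compound 1 gives 200 nM, while compound 2 gives 92400 nM, the higher of the two numbers and far beyond the usual scatter from compound 1. Compound 1 and compound 2 differ in two places at once, so their two values alone do not show which change carries the gap. Compound 3 `COc1ccc(C2=NN(C3=NC(=O)/C(=C4\C(=O)Nc5ccc(Br)cc54)S3)C(c3ccc(Cl)cc3)C2)cc1` differs from compound 2 in a single place: bromo in place of hydrogen on an aromatic carbon. Compound 3 thus carries the same bromo as compound 1 while keeping the chloro of compound 2. Within the data shown here, no measured pair isolates this change, but the only bromo-bearing compound, compound 1 with 200 nM, sits far lower, so a large downward step in this assay is expected, with wide uncertainty. The value for compound 3 is estimated at 5000 nM, between 500 nM and 50000 nM. This expectation amounts to an 18-fold lower number from compound 2 to compound 3 (1.27 log units; beyond the scatter).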

Compound 3, concentration for 50% growth inhibition: 120 nM
For compound 3 the middle estimate is 42-fold (1.62 log units) above the measured one; the whole stated range lies above it.
By their numbers in this assay, from the lowest: compounds 3 and 1 (each within the scatter of the next); then compound 2.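

In this assay, a single change, bromo in place of hydrogen on an aromatic carbon of the fused two-ring part, gives a 770-fold lower number from compound 2 to compound 3 (2.89 log units; beyond the scatter) and so carries most of the gap seen between the first two compounds. With bromo in place, chloro in place of methoxy on an aromatic carbon gives a 1.7-fold lower number from compound 1 to compound 3 (0.22 log units; within the scatter) and therefore shows no clear effect on growth inhibition here. Nothing available explains why bromo has so large an effect.

As far as these compounds go, it remains open whether this step is specific to bromo or would also appear with a fluoro, a methyl, an amine or a carboxylic acid at the same carbon. It is also unclear whether swapping chloro for methoxy would remain without clear effect in a compound lacking bromo.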